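A few compounds are considered here, and "the series" means these few. Any claim that something is new, unique, unknown or untested is made for them only; others in the source may bear on it.

Measured so far in a functional assay on the whole organism for inhibition, with Brassica napus as the target, with a stated time of 72 h, tested at 100 mg/L; on this read-out higher numbers stand for more inhibition of growth at the one concentration tested and lower numbers for less inhibition of growth:

Compound 1 `Cc1cc(O)nc(NC(=S)NC(=O)c2c(-c3ccc(Cl)cc3Cl)noc2C)n1` gives 52.3%.
Compound 2 `Cc1onc(-c2ccc(Cl)cc2Cl)c1C(=O)/N=c1/nc2nc(Cl)cc(C)n2s1` gives 70.2%.
Compound 3 `CSc1cc(C)nc2n/c(=N/C(=O)c3c(-c4ccc(Cl)cc4Cl)noc3C)sn12` gives 62.8%.

Among these three numbers compound 2 stands highest. Its nearest neighbour is compound 3, whose number lies lower by an amount that is still within the usual scatter of repeated measurements, so the two cannot be told apart with confidence. Compound 1 lies furthest away, and that gap is beyond the scatter, so compound 2 does inhibit growth more than compound 1.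

Compound 4 `COc1cc(Cl)nc2n/c(=N/C(=O)c3c(-c4ccc(Cl)cc4Cl)noc3C)sn12` has not yet been measured. It differs from compound 2 in one place: methoxy in place of methyl on an aromatic carbon. Among the measured compounds shown here, no pair of measured compounds shows what such an exchange does in this assay, so there is no measured step to lean on. An exchange of this small size gives no ground to expect a shift beyond the scatter in either direction, though the uncertainty is wider than for a measured step. Compound 4 is therefore expected to give about 65%, with a likely range from 45% to 85%. The step of a number 5.2 percentage points lower from compound 2 to compound 4 (within the scatter) that this estimate means is expected to be small and to stay within the scatter.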

Compound 4, percent growth inhibition at one concentration: 70.8%
Compound 4: the middle estimate sits 5.8 percentage points below what was measured; measured number inside the range.
By their numbers in this assay, from the lowest: compound 1; then compounds 3, 2 and 4 (each within the scatter of the next).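

In this assay the exchange of methyl for methoxy on this aromatic carbon gives a number 0.6 percentage points higher from compound 2 to compound 4 (within the scatter) and so the two compounds cannot be told apart. Among the compounds shown here, this is the first measured exchange at this place, on the six-membered aromatic ring with 2 nitrogen and next to the ring nitrogen, and it shows that the read-out stays within the scatter when methoxy, with its oxygen counted as a hydrogen-bond acceptor, stands there instead of methyl. No measurement is at hand that bears on why these two compounds lie so close together.

On these data alone, whether an amine or a longer chain such as ethoxy on this same carbon would also stay within the scatter of compound 2 remains open, and one exchange of this small size cannot show how far the position's tolerance reaches. As far as these compounds go, it is also open whether methyl and methoxy would compare in the same way with a group other than the chloro group on this ring, or at a lower concentration, since the read-out covers a single concentration.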